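A few compounds are considered here, and "the series" means these few. Any claim that something is new, unique, unknown or untested is made for them only; others in the source may bear on it.

Within the data shown here, in a functional assay on MCF7 cells (Homo sapiens) for inhibition, read by MTT assay, with a stated time of 48 h (a lower number here means a stronger inhibitor, a higher number a weaker inhibitor), three compounds have numbers so far. Compound 2 (`c1ccc(-c2nn(-c3ccccc3)c3nccc(-c4cccs4)c23)cc1`) gives 39300 nM as the highest of the three. Compound 3 (`O=C(C=CNc1cc(-c2ccccc2)nn1-c1ccccc1)c1cccs1`) gives 15400 nM and lies nearest, and compound 1 (`COc1ccc(C(=O)C=CNc2cc(-c3ccccc3)nn2-c2ccccc2)cc1`) gives 1290 nM and lies furthest, with both gaps beyond the scatter.

Compound 4 (`Brc1ccc(-c2ccnc3c2c(-c2ccccc2)nn3-c2ccccc2)cc1`) keeps the core of compound 2 and carries 4-bromophenyl in place of thiophen-2-yl on an aromatic carbon, opposite the ring nitrogen (4-bromophenyl in place of thiophen-2-yl on an aromatic carbon). Among the measured compounds shown here, only one measured step bears on this change. Read in reverse, the large step of a 12-fold higher number from compound 1 to compound 3 (1.08 log units; beyond the scatter) on a carbonyl carbon of a different core, where thiophen-2-yl replaces 4-methoxyphenyl, points to a lower number in this assay for compound 4. The entering group here is not 4-methoxyphenyl and the core differs, so only part of that size is carried over. The step is expected to be a 3.9-fold lower number from compound 2 to compound 4 (0.59 log units; beyond the scatter) toward a stronger inhibitor. Compound 4 is estimated at 10000 nM with an expected range from 2500 nM to 40000 nM around that value.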

Compound 4, half-maximal inhibitory concentration: 13300 nM
For compound 4 the middle estimate is 1.3-fold (0.12 log units) below the measured one; the range from low to high includes it.
By their numbers in this assay, from the lowest: compound 1; then compounds 4 and 3 (each within the scatter of the next); then compound 2.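

In this assay, the aromatic carbon opposite the ring nitrogen responds to a change of group, showing a 3.0-fold lower number from compound 2 to compound 4 (0.47 log units; beyond the scatter) with 4-bromophenyl in place of thiophen-2-yl. Thiophen-2-yl therefore goes with the higher number in both pairs that carry it, here and on the carbonyl carbon of the other core, which shows a 12-fold higher number from compound 1 to compound 3 (1.08 log units; beyond the scatter) against 4-methoxyphenyl, although the group compared differs between the two pairs. Nothing measured on hand explains this step.

On these data alone, it remains open whether the bromine matters or whether the six-membered aromatic ring of carbon alone accounts for the step, a question that unsubstituted phenyl at this carbon would address. As far as these compounds go, how 4-methoxyphenyl, an amine or a carboxylic acid would read at this place also remains open.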